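This account rests on a few compounds, and the source may have more. Where it says the series, first, only, none or still open, it means among the compounds named here.

Measured so far:
compound 1 `CCC(=O)Nc1ncc(-c2ccc(OC)cc2)n1C`, > 100000 nM
compound 2 `COc1ccc(-c2cnc(NC(=O)c3ccc(F)cc3)n2C)cc1`, >= 50000 nM

In a toxicity assay on THP-1 cells (Homo sapiens) for inhibition (a lower number here means that less compound is tolerated, a higher number that more compound is tolerated), compound 1 gives only a limit, > 100000 nM. Compound 2 likewise gives only a limit, >= 50000 nM. The step that the two limits leave unreadable from compound 1 to compound 2 is therefore unreadable, both values being limits: the limit of > 100000 nM in this assay, at which 1 of the 2 values shown sits, and (the limit of >= 50000 nM in this assay, at which 1 of the 2 values shown sits). Compound 3 `COc1ccc(C(=O)Nc2ncc(-c3ccc(OC)cc3)n2C)cc1` differs from compound 2 by methoxy in place of fluoro on an aromatic carbon. For the measured compounds named here, no measured step bears on this exchange, and compound 2 stands at a limit, so no direction is indicated. Compound 3 is expected at 100000 nM, range 30000 nM to 300000 nM, most likely again a limit. The expected step is a step that the limit leaves unreadable from compound 2 to compound 3, not beyond scatter.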

Compound 3, half-maximal cytotoxic concentration: > 100000 nM
Compound 3: a limit, no number; the forecaster's own chance of this, stated with the estimate: 80%; the middle value lies on the limit itself.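

In this assay compound 3 gives only a limit, > 100000 nM. No step can be read among compound 1, compound 2 and compound 3, since all three values are limits. Left open is whether the group on the carbonyl carbon changes tolerated concentration at all.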